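Adding a second chlorine to the shared core of compound 2

This account rests on a few compounds, and the source may have more. Where it says the series, first, only, none or still open, it means among the compounds named here.

Measured so far:
compound 1 `ClCc1cccc(Cn2cnc3ncnc(Cl)c32)c1` — 3090 nM
compound 2 `ClCc1cccc(Cn2cnc3c(Cl)ncnc32)c1` — 1950 nM
compound 3 `ClCc1ccc(Cn2cnc3nc(Cl)nc(Cl)c32)cc1` — 1620 nM

In a functional assay on LOX IMVI cells (Homo sapiens) for cytotoxicity, read by sulforhodamine B assay, with a stated time of 48 h (a lower number here means a stronger inhibitor of growth, a higher number a weaker inhibitor of growth), compound 2 gives 1950 nM. The other two numbers lie on either side of it: compound 3 gives 1620 nM and compound 1 gives 3090 nM, and each of these gaps from compound 2 is within the scatter, so the three measured compounds cannot be told apart on these numbers.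

Compound 4 `ClCc1cccc(Cn2cnc3c(Cl)nc(Cl)nc32)c1` has not yet been measured. It differs from compound 2 by chloro in place of hydrogen on an aromatic carbon. Within the data shown here, no pair of measured compounds differs in one place only, so no measured step tells how much such a change is worth here. Among the measured compounds shown here, the only hint is compound 3, which carries two chlorines on its core and gives 1620 nM, a number within the scatter of compound 2.

On that basis the step is expected to be small, and the number for compound 4 is expected to sit close to that of compound 2, perhaps a little lower, with the expected step being a 1.3-fold lower number from compound 2 to compound 4 (0.11 log units; within the scatter). Compound 4 is therefore estimated at 1500 nM, with a range from 500 nM to 4500 nM.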

Compound 4, concentration for 50% growth inhibition: 1690 nM
For compound 4 the middle estimate is 1.1-fold (0.05 log units) below the measured one; measured number inside the range.
By their numbers in this assay, from the lowest: compounds 3, 4, 2 and 1 (each within the scatter of the next).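

In this assay, among these compounds, the replacement of hydrogen by chloro on an aromatic carbon between two ring nitrogen atoms comes to a 1.2-fold lower number from compound 2 to compound 4 (0.06 log units; within the scatter) and gives the first reading of a change in one place only. The earlier compounds shown here offered no such pair, whereas here the added chlorine is the sole difference, and the two compounds cannot be told apart on these numbers. So this carbon can carry a chloro group with no difference that this assay can resolve, though the data offered here give no explanation for that outcome.

What this single replacement leaves open is whether a larger or different group on the same carbon, such as an amine, a methoxy group or a longer chain, would give a number that lies beyond the scatter from that of compound 2. From the compounds shown here alone, it also remains open whether chloro in place of hydrogen at this carbon would read the same on the core of compound 1, or in a compound with its chloromethyl group placed as in compound 3.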